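A few compounds are considered here, and "the series" means these few. Any claim that something is new, unique, unknown or untested is made for them only; others in the source may bear on it.

Working notes on the series. In a functional assay on the whole organism with Mus musculus as the target (on this read-out higher numbers stand for an effect only at larger amounts of compound and lower numbers for an effect already at smaller amounts), compound 1 (`O=C1CCC(O)(c2cccc(C(F)(F)F)c2)N1`) gives > 200 mg/kg as a limit and not a number. Compound 3 (`CCCCN1C(=O)CCC1(O)c1cccc(C(F)(F)F)c1`) likewise gives > 200 mg/kg as a limit. For the measured compounds named here, compound 2 (`CN1C(=O)CCC1(O)c1cccc(C(F)(F)F)c1`) gives 133 mg/kg and holds the only actual number of the three.

Compound 4 (`Cc1cccc(C2(O)CCC(=O)N2C)c1`) differs from compound 2 by a single change (methyl in place of trifluoromethyl on an aromatic carbon) and carries methyl in place of trifluoromethyl on an aromatic carbon.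

The measured steps all concern the group on the amide-type nitrogen: one is (an at least 1.5-fold lower number from compound 1 to compound 2 (0.17 log units; that floor lies within the scatter)), another (an at least 1.5-fold higher number from compound 2 to compound 3 (0.17 log units; that floor lies within the scatter)), and the third (a step that the two limits leave unreadable from compound 1 to compound 3). None of them alters the aromatic carbon in question, so none gives a size or direction for this change. No step beyond the scatter is therefore expected in this assay, and no direction is assigned. The expected size is a 1.1-fold higher number from compound 2 to compound 4 (0.05 log units; within the scatter) on this estimate. Going by the values given here, the expectation is anchored on compound 2 at 133 mg/kg as the only number available. With the limit of > 200 mg/kg in this assay, at which 2 of the 3 values shown sit, in view, a limit result for compound 4 also remains possible. For compound 4 the estimated value is 150 mg/kg with an expected range from 70 mg/kg to 300 mg/kg as the likely span.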

Compound 4, dose for half-maximal effect: 138 mg/kg
The estimate for compound 4 lay 1.1-fold (0.04 log units) above the measured number; measured number inside the range.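

In this assay, for the compounds shown here, methyl in place of trifluoromethyl on an aromatic carbon gives a 1.0-fold higher number from compound 2 to compound 4 (0.02 log units; within the scatter), the first readable step at this position and the first between two actual numbers rather than against a limit. The earlier compounds shown here varied only the group on the amide-type nitrogen, whereas this pair shows that the read-out does not separate trifluoromethyl from methyl at this aromatic carbon. The fluorine atoms are therefore not required for an effect in this dose range, at least with methyl on the amide-type nitrogen, and this finding rests on this single pair.

From the compounds shown here alone, it remains open whether other groups on this aromatic carbon, such as hydrogen, chlorine, methoxy, an amine or a carboxylic acid, would also stay within the scatter, and whether the same exchange would read alike with hydrogen or butyl on the amide-type nitrogen. Any such comparison may also fail to yield a number, because results in this series often end at a limit rather than a value: the limit of > 200 mg/kg in this assay, at which 2 of the 4 values shown sit.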